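The compounds below may be only part of what the source reports. "The series", "measured", "known", "first", "only" and "open" are said of these compounds alone.

Working notes on a small series tested in a functional assay on HT-29 cells (Homo sapiens) for cytotoxicity, read by fluorescence and resazurin assay, with a stated time of 48 h; a lower number here means a stronger inhibitor, a higher number a weaker inhibitor.

Going by the values given here, compound 1 `COc1ccc(/C=C/c2cc(/C=C/c3ccc(OC)cc3)nc(OCCCCCBr)n2)cc1` is the first of a pair built on one core. In this assay compound 1 reaches only the limit > 20000 nM. Compound 2 `COc1ccc(/C=C/c2cc(/C=C/c3ccc(OC)cc3)nc(OCCCCBr)n2)cc1` differs from compound 1 by bromo in place of bromomethyl on a saturated chain carbon, four bonds along the chain from an oxygen on an aromatic ring. In this assay compound 2 likewise gives only the limit > 20000 nM. The step that the two limits leave unreadable from compound 1 to compound 2 has no readable size because both ends sit at the limit of > 20000 nM in this assay, at which 3 of the 3 values shown sit.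

Compound 3 `COc1ccc(/C=C/c2cc(/C=C/c3ccc(OC)c(OC)c3)nc(OCCCCCCBr)n2)cc1OC` rests on a second core; the difference between the core of compound 1 and the core of compound 3 is not broken down here. In this assay compound 3 also gives only the limit > 20000 nM.

Compound 4 `COc1ccc(/C=C/c2cc(/C=C/c3ccc(OC)c(OC)c3)nc(OCCCCCBr)n2)cc1OC` has not yet been measured and differs from compound 3 by bromo in place of bromomethyl on a saturated chain carbon, five bonds along the chain from an oxygen on an aromatic ring. This is the same kind of change as that from compound 1 to compound 2, but not the same one: there the place is four bonds along the chain from an oxygen on an aromatic ring, here it is five bonds along the chain from an oxygen on an aromatic ring. The measured version of this change gave no readable size, and every value so far sits at the limit of > 20000 nM in this assay, at which 3 of the 3 values shown sit, so no member of the series has yet shown a number rather than a limit. Compound 4 is therefore expected to stay at the limit as well, with an estimate of 30000 nM. The expected step from compound 3 is a step that the limit leaves unreadable from compound 3 to compound 4, resting on the unreadable step that the two limits leave unreadable from compound 1 to compound 2 and on compound 3 sitting at > 20000 nM.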

Compound 4, half-maximal inhibitory concentration: > 20000 nM
Compound 4 was reported as a limit; the forecaster's own chance of this, stated with the estimate: 85%; the middle value does not contradict the limit.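

Compound 3 and compound 4 both end at a limit, so no size can be read for the step between them, and the series offers no new comparison: the limit of > 20000 nM in this assay, at which 4 of the 4 values shown sit. The compounds shown leave open whether chain length or the difference between the two cores has any bearing on the half-maximal inhibitory concentration, with no member yet giving a number rather than a limit.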